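A few compounds are considered here, and "the series" means these few. Any claim that something is new, unique, unknown or untested is made for them only; others in the source may bear on it.

In a functional assay on PC-3 cells (Homo sapiens) for inhibition, read by sulforhodamine B assay, with a stated time of 48 h (a lower number here means a stronger inhibitor of growth, a higher number a weaker inhibitor of growth), compound 3 (`CC(C)(C)NCc1c(C(=O)O)nn(-c2ccc(Cl)cc2)c1-c1ccc(Br)cc1`) gives > 542000 nM which is a limit and not a number. Compound 2 (`CC(C)(C)NCc1c(C(=O)O)nn(-c2ccc(Cl)cc2)c1-c1ccc(F)cc1`) gives > 623000 nM which is likewise a limit. Compound 1 (`CCOC(=O)c1nn(-c2ccc(Cl)cc2)c(-c2ccccc2)c1CNC(C)(C)C`), a relative of both, gives > 608000 nM; > 559000 nM (2 entries) and these entries are limits too. Compound 4 (`CC(C)(C)NCc1c(C(=O)O)nn(-c2ccc(Cl)cc2)c1-c1ccccc1`) differs from compound 3 by a single change (hydrogen in place of bromo on an aromatic carbon): hydrogen in place of bromo on an aromatic carbon, so 4-bromophenyl becomes phenyl. The nearest measured change (a step that the two limits leave unreadable from compound 2 to compound 3) has no readable size, as both its ends are limits. No step beyond the scatter is therefore expected, in either direction, and a further limit is the likeliest result. The estimated move (a step that the limit leaves unreadable from compound 3 to compound 4) is expected to stay small. For compound 4 the estimate is 650000 nM with 350000 nM to 1000000 nM as the expected range.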

Compound 4, concentration for 50% growth inhibition: > 652000 nM
Compound 4: no number, only a limit; the forecaster's own chance of this, stated with the estimate: 90%; at least 1.0-fold (0.00 log units) between middle value and limit.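

For the compounds shown here, compound 2, compound 3 and compound 4 each give only a limit in this assay, so no step among them can be read. The compounds shown leave open whether fluoro, bromo or hydrogen at this place changes growth inhibition at all.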